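A few compounds are considered here, and "the series" means these few. Any claim that something is new, unique, unknown or untested is made for them only; others in the source may bear on it.

In a toxicity assay (L6 cells) for inhibition, with Rattus norvegicus as the target, read by resazurin assay, with a stated time of 70 h (on this read-out higher numbers stand for weaker inhibition and lower numbers for stronger inhibition), compound 1 `Clc1ccc2c(NCCN3CCCCCC3)ccnc2c1` gives 13200 nM and compound 2 `Clc1ccc2c(NCCCN3CCCCCC3)ccnc2c1` gives 20000 nM, so compound 2 stands level with compound 1 within the scatter. Compound 3 `CN1CCN(CCCNc2ccnc3cc(Cl)ccc23)CC1` is compound 2 with one change: 4-methylpiperazin-1-yl in place of azepan-1-yl on a saturated chain carbon, three bonds along the chain from a nitrogen on an aromatic ring. Here 4-methylpiperazin-1-yl replaces azepan-1-yl on a saturated chain carbon, three bonds along the chain from a nitrogen on an aromatic ring. Among the compounds with values here, no measured pair shows this change, so the expectation is tentative: no step beyond the scatter, with a slight lean toward weaker inhibition. The estimated step is a 1.6-fold higher number from compound 2 to compound 3 (0.20 log units; within the scatter). Compound 3 is expected at 32000 nM, within an estimated range of 12000 nM to 85000 nM.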

Compound 3, half-maximal inhibitory concentration: 18200 nM
Estimate against measurement, compound 3: 1.8-fold (0.25 log units) above, and the stated range covers the measured number.
By their numbers in this assay, from the lowest: compounds 1, 3 and 2 (each within the scatter of the next).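

In this assay, 4-methylpiperazin-1-yl in place of azepan-1-yl on a saturated chain carbon, three bonds along the chain from a nitrogen on an aromatic ring, gives a 1.1-fold lower number from compound 2 to compound 3 (0.04 log units; within the scatter) and so separates the two compounds by no more than the scatter. At this place, a seven-membered ring with 1 hetero atom and a six-membered ring with 2 hetero atoms therefore read alike. Nothing available explains this result. The compounds shown leave open how a morpholine or an open-chain diethylamino group would read at this place. They also leave open whether a carboxylic acid on the chain would give a step beyond the scatter.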